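Dropping the chloro from compound 2: what to expect

The compounds below may be only part of what the source reports. "The series", "measured", "known", "first", "only" and "open" are said of these compounds alone.

Measured compounds:
compound 1, `COc1cccc(-c2nn3cc(-c4cccc(N)c4)nc3s2)c1`, > 250000 nM
compound 2, `Nc1cccc(-c2cn3c(-c4ccc(Cl)cc4)csc3n2)c1`, 21000 nM

Of the compounds shown here, two have been tested in a functional assay on CCRF-CEM cells (Homo sapiens) for inhibition, read by cell counting, with a stated time of 3 days; on this read-out lower numbers stand for stronger inhibition and higher numbers for weaker inhibition. Compound 1 gives > 250000 nM, which is a limit of the assay rather than a number. Compound 2, with the same amine-bearing ring attached to a different core, gives 21000 nM; this is the only number shown.

The new compound is compound 3, `Nc1cccc(-c2cn3c(-c4ccccc4)csc3n2)c1`. It differs from compound 2 in a single place: hydrogen in place of chloro on an aromatic carbon, that is, 4-chlorophenyl becomes phenyl.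

For the measured compounds named here, no pair of measured compounds differs in only one place, so no measured step guides this change. The expected step from compound 2 to compound 3 is a 2.1-fold higher number from compound 2 to compound 3 (0.33 log units; beyond the scatter), a modest loss of inhibition that barely exceeds the scatter of repeated measurements. Compound 3 is therefore estimated at 45000 nM, with a likely range from 15000 nM to 150000 nM.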

Compound 3, half-maximal inhibitory concentration: 29000 nM
The estimate for compound 3 lay 1.6-fold (0.19 log units) above the measured number; low and high end bracket the measured number.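

Removing the chloro, so that 4-chlorophenyl becomes phenyl, gives this assay its first comparison between compounds that differ in one place: a 1.4-fold higher number from compound 2 to compound 3 (0.14 log units; within the scatter). On this single comparison, the chloro on this aromatic carbon, para to a large group, can be exchanged for hydrogen without a difference that repeated measurements of this kind could separate from noise. Nothing measured here bears on why the chloro counts for so little at this position.

On these data alone, whether a larger or different group, such as methoxy, an amine or a carboxylic acid, would shift the number at this position remains open. So does whether the same exchange would behave alike on the core of compound 1.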